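Aryl sulfonyl series: fluoro to bromo step pending

The compounds below may be only part of what the source reports. "The series", "measured", "known", "first", "only" and "open" are said of these compounds alone.

Compound 1 `CN(C)c1ccc(C2CC(c3ccc(-n4cncn4)cc3)=NN2C(=O)c2ccc(C(F)(F)F)cc2)cc1` and compound 2 `CN(C)c1ccc(C2CC(c3ccc(-n4cncn4)cc3)=NN2S(=O)(=O)c2ccc(F)cc2)cc1` share one core and differ only on the ring amine nitrogen. In a functional assay on MDA-MB-231 cells (Homo sapiens) for inhibition, read by sulforhodamine B assay, tested at 10 uM (a higher number here means more inhibition at the concentration tested (going by the name of the read-out), a lower number less inhibition), compound 1 gives 16.7% and compound 2 gives 12.1%. Among the compounds with values here, the single measured step, a number 4.6 percentage points lower from compound 1 to compound 2 (within the scatter), replaces (4-(trifluoromethyl)phenyl)carbonyl with (4-fluorophenyl)sulfonyl and lands within the scatter, so the two numbers cannot be ranked against each other; compound 2 simply sits at the same level as compound 1.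

Compound 3 `CN(C)c1ccc(C2CC(c3ccc(-n4cncn4)cc3)=NN2S(=O)(=O)c2ccc(Br)cc2)cc1` is not yet measured. It differs from compound 2 by bromo in place of fluoro on an aromatic carbon. Within the data shown here, no measured step touches this position: the only step on record changes the whole group on the ring nitrogen, not a substituent on the (4-fluorophenyl)sulfonyl ring, so it gives no direction for a halogen exchange there. Both measured numbers are low and close to each other, and nothing in the series points to a change beyond the scatter.

Compound 3 is therefore expected to stay near compound 2, with a step of about a number 1.9 percentage points higher from compound 2 to compound 3 (within the scatter), estimated at 14% with a range from 2% to 30%.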

Compound 3, a percentage reported as inhibition, at one concentration (the size of the read-out at that concentration, not a potency): 10.4%
Compound 3: the middle estimate sits 3.6 percentage points above what was measured; the measured number falls inside the stated range.
By their numbers in this assay, from the lowest: compounds 3, 2 and 1 (each within the scatter of the next).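

In this assay the halogen on this ring now has a measured step of its own: a number 1.7 percentage points lower from compound 2 to compound 3 (within the scatter) for bromo in place of fluoro on an aromatic carbon para to a large group. Within the scatter, compound 3 therefore stands at the level of compound 2, and the two halogens cannot be ranked at this position. The exchange on the ring nitrogen, a number 6.3 percentage points lower from compound 1 to compound 3 (within the scatter) for (4-bromophenyl)sulfonyl in place of (4-(trifluoromethyl)phenyl)carbonyl, likewise does not separate compound 3 from compound 1. No measurement shown offers an explanation for the size of these steps.

From the compounds shown here alone, whether a different kind of group on this aromatic carbon, such as an amine, a carboxylic acid or a methoxy group, would give a step beyond the scatter remains open. The compounds shown also change the carbonyl or sulfonyl link only together with the substituent on the aromatic ring, so the contributions of the link and the substituent cannot be told apart.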